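Side-chain change from compound 2 to compound 3

This account rests on a few compounds, and the source may have more. Where it says the series, first, only, none or still open, it means among the compounds named here.

Among the measured compounds shown here, only two compounds have numbers so far. In a functional assay on PC-3 cells (Homo sapiens) for antiproliferative activity, read by MTT assay, with a stated time of 72 h (on this read-out lower numbers stand for stronger inhibition and higher numbers for weaker inhibition), compound 1 (`O=C(N/N=C/c1cccc(Br)c1)Nc1ccc(Oc2ccnc3[nH]ccc23)c(F)c1`) gives 4020 nM and compound 2 (`CN(C)CCn1cccc1/C=N/NC(=O)Nc1ccc(Oc2ccnc3[nH]ccc23)c(F)c1`) gives 1600 nM, which puts compound 2 lowest of the two. For the measured compounds named here, the one measured step, a 2.5-fold lower number from compound 1 to compound 2 (0.40 log units; beyond the scatter), is modest but beyond the scatter. It places 1-(2-(dimethylamino)ethyl)-1H-pyrrol-2-yl where 3-bromophenyl stood.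

Compound 3 (`CN1CCN(CCCn2cccc2/C=N/NC(=O)Nc2ccc(Oc3ccnc4[nH]ccc34)c(F)c2)CC1`) differs from compound 2 in one place: (4-methylpiperazin-1-yl)methyl in place of dimethylamino on a saturated chain carbon, two bonds along the chain from an aromatic nitrogen. In words, (4-methylpiperazin-1-yl)methyl stands in place of dimethylamino on a saturated chain carbon, two bonds along the chain from an aromatic nitrogen. Cut one bond further out, the same difference reads 2-(dimethylamino)ethyl to 3-(4-methylpiperazin-1-yl)propyl.

Going by the values given here, no measured step covers this exchange. The only one available, a 2.5-fold lower number from compound 1 to compound 2 (0.40 log units; beyond the scatter), replaced a different group, so it bears only indirectly and sets a modest scale at most. No step beyond the scatter is therefore expected in this assay. The expected move is a 1.1-fold lower number from compound 2 to compound 3 (0.03 log units; within the scatter). For compound 3 the estimated value is 1500 nM, with an expected range of 500 nM to 4500 nM.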

Compound 3, half-maximal inhibitory concentration: 2190 nM
The estimate for compound 3 lay 1.5-fold (0.16 log units) below the measured number, and the stated range covers the measured number.
By their numbers in this assay, from the lowest: compounds 2, 3 and 1 (each within the scatter of the next, the first and the last beyond it).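

In this assay, putting (4-methylpiperazin-1-yl)methyl in place of dimethylamino on a saturated chain carbon, two bonds along the chain from an aromatic nitrogen, gives a 1.4-fold higher number from compound 2 to compound 3 (0.14 log units; within the scatter). This position therefore accepts a group of 8 heavy atoms with one six-membered non-aromatic ring in place of one of 3 heavy atoms with no ring, with no step beyond the scatter in this read-out, whereas the earlier step, a 2.5-fold lower number from compound 1 to compound 2 (0.40 log units; beyond the scatter), exchanged the whole group on the carbon with a double bond to nitrogen and said nothing about the chain end alone. No measurement at hand bears on why the number stays within the scatter across this change.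

The compounds shown leave open whether chain length and the end group act separately, as the step from 2-(dimethylamino)ethyl to 3-(4-methylpiperazin-1-yl)propyl alters both at once, and a 3-(dimethylamino)propyl or a 2-(4-methylpiperazin-1-yl)ethyl group would pull them apart. They also leave open whether an amine is needed at the chain end at all, a question that a chain ending in a hydroxyl group or a carboxylic acid would address.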